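The compounds below may be only part of what the source reports. "The series", "measured", "known", "first", "only" and "open" are said of these compounds alone.

In a functional assay on HeLa cells (Homo sapiens) for cytotoxicity, read by MTT assay, with a stated time of 48 h, in the absence of a further agent (on this read-out higher numbers stand for weaker inhibition and lower numbers for stronger inhibition), compound 2 `COc1ccc(NC(=O)c2csc(-c3cn(Cc4ccc(Cl)cc4)c4ccccc34)n2)cc1` reaches only the limit of the assay, > 100000 nM, so no number is known for it. Compound 3 `COc1cc(NC(=O)c2csc(-c3c[nH]c4ccc(F)cc34)n2)cc(OC)c1OC` likewise gives only a limit, > 100000 nM. Compound 1 `O=C(NCc1ccccc1)c1csc(-c2c[nH]c3ccccc23)n1` gives 9510 nM. Compound 2 therefore stands at the limit of > 100000 nM in this assay, at which 2 of the 3 values shown sit. Compound 4 `COc1cc(NC(=O)c2csc(-c3cn(Cc4ccc(Cl)cc4)c4ccccc34)n2)cc(OC)c1OC` differs from compound 2 in one place: 3,4,5-trimethoxyphenyl in place of 4-methoxyphenyl on an amide-type nitrogen. For the measured compounds named here, no measured pair isolates this change. Compound 3 already carries the 3,4,5-trimethoxyphenyl group on its amide nitrogen and returns only a limit, > 100000 nM. On that basis the step from compound 2 to compound 4 is expected to be none beyond the scatter, a number no higher from compound 2 to compound 4 (the limit leaves the size open). Compound 4 is expected to give about 100000 nM, between 30000 nM and 300000 nM, most likely again only a limit.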

Compound 4, half-maximal inhibitory concentration: 91400 nM
Beside the measured number, compound 4's estimate is 1.1-fold (0.04 log units) above it; the measured number falls inside the stated range.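

In this assay, compound 4 returns a measured number, whereas compound 2 returns only a limit, so 3,4,5-trimethoxyphenyl on this amide-type nitrogen gives a readable result. The step is an at least 1.0-fold lower number from compound 2 to compound 4 (0.03 log units; that floor lies within the scatter), so it shows no real gain from the two added methoxy groups, though a larger true step remains possible. Compound 2 marks only the edge of what the test can read: the limit of > 100000 nM in this assay, at which 2 of the 4 values shown sit.

From the compounds shown here alone, whether a phenyl ring carrying an amine or a carboxylic acid in place of the methoxy groups would give a clearly lower number on this nitrogen remains open.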